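Aryl amides on a shared core: tolerance in THP-1 cells

The compounds below may be only part of what the source reports. "The series", "measured", "known", "first", "only" and "open" are said of these compounds alone.

Measured compounds:
- compound 1, `COc1ccc(-c2cnc(NC(=O)c3ccco3)n2C)cc1`, in a toxicity assay on THP-1 cells (Homo sapiens) for inhibition (a lower number here means that less compound is tolerated, a higher number that more compound is tolerated), compound 1 gives > 100000 nM, a limit of the assay
- compound 2, `COc1ccc(-c2cnc(NC(=O)c3cnco3)n2C)cc1`, in this assay compound 2 gives > 100000 nM, a limit of the assay
- compound 3, `COc1ccc(-c2cnc(NC(=O)c3cccc(F)c3)n2C)cc1`, in this assay compound 3 gives > 100000 nM, a limit of the assay

Compound 3 stands where the two other measured compounds stand: all three values in this assay are limits, and no number separates them. This is summed up by the limit of > 100000 nM in this assay, at which 3 of the 3 values shown sit. The steps a step that the two limits leave unreadable from compound 1 to compound 2, a step that the two limits leave unreadable from compound 1 to compound 3 and a step that the two limits leave unreadable from compound 2 to compound 3 are therefore unreadable in size and direction; they only show that exchanging one aryl or heteroaryl group on the carbonyl carbon for another left every compound beyond the reach of the assay.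

Compound 4, `COc1ccc(-c2cnc(NC(=O)c3ccc(Cl)cc3)n2C)cc1`, differs from compound 3 in one place: 4-chlorophenyl in place of 3-fluorophenyl on a carbonyl carbon. Within the data shown here, none of the measured steps can bear a readable size on this change, since each ends at the limit. The expectation is therefore that compound 4 behaves like compound 3, with the step that the limit leaves unreadable from compound 3 to compound 4 estimated as none beyond the scatter, and most likely again only a limit. For compound 4 in this assay the estimated value is 150000 nM, within a range from 50000 nM to 500000 nM.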

Compound 4, half-maximal cytotoxic concentration: > 100000 nM
Compound 4 gave a limit, no number (the forecaster's own chance of this, stated with the estimate: 85%); the middle value lies beyond the limit too.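

Compound 4 sits at a limit in this assay, as do compound 1, compound 2 and compound 3, so no step to compound 4 can be read in size or direction: the limit of > 100000 nM in this assay, at which 4 of the 4 values shown sit.

The compounds shown leave open what concentration would be half-maximally cytotoxic for any of the four, and whether any group on the carbonyl carbon would bring a compound within reach of this assay.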